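From Chloro to Trifluoromethyl: Expected Hepatic Extraction

A few compounds are considered here, and "the series" means these few. Any claim that something is new, unique, unknown or untested is made for them only; others in the source may bear on it.

Measured so far:
compound 1 `CCC(CC)n1c(=O)[nH]c2ncc(C)nc21`: 0.7
compound 2 `CCC(CC)n1c(=O)[nH]c2ncc(Cl)nc21`: 0.4

Of the compounds shown here, two sharing one core have been tested in an ADME assay on microsomes from liver (Rattus norvegicus), read by LC-MS, with a stated time of 90 min; on this read-out higher numbers stand for higher hepatic extraction and lower numbers for lower hepatic extraction. Compound 1 `CCC(CC)n1c(=O)[nH]c2ncc(C)nc21` gives 0.7. Among the compounds with values here, compound 2 `CCC(CC)n1c(=O)[nH]c2ncc(Cl)nc21` gives 0.4, the lowest of the two numbers, and the single measured step, a number 0.30 lower from compound 1 to compound 2 (beyond the scatter), lies beyond the scatter.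

Compound 3 `CCC(CC)n1c(=O)[nH]c2ncc(C(F)(F)F)nc21` has not been measured. It differs from compound 2 in one place: trifluoromethyl in place of chloro on an aromatic carbon.

Within the data shown here, no measured step covers this exact change. Among the measured compounds shown here, the only step on record, a number 0.30 lower from compound 1 to compound 2 (beyond the scatter), shows that swapping the group at this position can shift the read-out by a modest amount, but it says nothing direct about trifluoromethyl. The expectation in this assay is therefore a small step, most likely within the scatter, with the direction uncertain and a wide range kept around it. Compound 3 is expected to give about 0.35, between 0.15 and 0.6. The expected step is a number 0.050 lower from compound 2 to compound 3 (within the scatter).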

Compound 3, hepatic extraction ratio: 0.2
Compound 3: the middle estimate sits 0.15 above what was measured, and the stated range covers the measured number.
By their numbers in this assay, from the lowest: compound 3; then compound 2; then compound 1.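

In this assay, trifluoromethyl in place of chloro on this aromatic carbon is not a neutral exchange: it gives a number 0.20 lower from compound 2 to compound 3 (beyond the scatter) and so shows that the read-out can still move after chloro has already lowered it. Trifluoromethyl in place of methyl gives a number 0.50 lower from compound 1 to compound 3 (beyond the scatter) and this is the largest step seen at this position, which now gives three groups a clear order on the shared core: methyl highest, chloro in the middle and trifluoromethyl lowest. The order describes only these three compounds, and no measurement shown here explains it.

The compounds shown leave open where other groups on this same aromatic carbon would fall in that order, for example an amine, a nitrile, a methoxy group or a longer chain such as ethyl. They also leave open whether the same exchanges would move the numbers as far with a different chain elsewhere on the core, or whether the order would hold in any read-out other than this assay.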